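Neopentyl for 3-chlorophenyl on the hydroxyacyl side chain

The source may hold more compounds than are shown below. What is called first, only, known or untested is meant among the compounds shown, and "the series" means these compounds.

Measured compounds:
- compound 1, `O=C(NCc1cc(Cl)ccc1-n1cnnn1)[C@@H]1C[C@@H]2C[C@@H]2N1C(=O)[C@H](O)c1cccc(Cl)c1`: 1000 nM
- compound 2, `CC(C)(C)OC[C@@H](O)C(=O)N1N=CC[C@H]1C(=O)NCc1cc(Cl)ccc1-n1cnnn1`: 750 nM

Of the compounds shown here, two have been measured in a functional assay on a cell-free system (plasma, Homo sapiens), with a stated time of 3 min; on this read-out lower numbers stand for stronger inhibition and higher numbers for weaker inhibition. Compound 1 gives 1000 nM, the highest of the two numbers, and compound 2 gives 750 nM; the two values lie within the scatter of each other, so neither can be called the stronger inhibitor on this evidence. Compound 3, `CC(C)(C)C[C@@H](O)C(=O)N1[C@H](C(=O)NCc2cc(Cl)ccc2-n2cnnn2)C[C@@H]2C[C@@H]21`, has not yet been measured in this assay. It differs from compound 1 in one place: neopentyl in place of 3-chlorophenyl on a saturated chain carbon bound to a carbonyl carbon and an oxygen on a saturated carbon. Compound 2 also carries a saturated, non-aromatic group at the corresponding position rather than an aromatic ring, and its value is not separated from that of compound 1 beyond the scatter. On that basis compound 3 is expected to stay close to compound 1, with an estimated step of a 1.4-fold lower number from compound 1 to compound 3 (0.15 log units; within the scatter), that is, no change beyond the usual scatter. The estimate for compound 3 in this assay is 700 nM, with a range from 250 nM to 2000 nM.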

Compound 3, half-maximal inhibitory concentration: 570 nM
The estimate for compound 3 lay 1.2-fold (0.09 log units) above the measured number, within the range that was stated.
By their numbers in this assay, from the lowest: compounds 3, 2 and 1 (each within the scatter of the next).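

In this assay, going by these compounds alone, the exchange of 3-chlorophenyl for neopentyl gives a 1.8-fold lower number from compound 1 to compound 3 (0.24 log units; within the scatter) and so offers the first comparison in which this position alone changes while the rest of the molecule stays the same. At this place, on a saturated chain carbon bound to a carbonyl carbon and an oxygen on a saturated carbon, the six-membered aromatic ring and its chlorine can give way to a ring-free carbon group with fewer heavy atoms without a shift beyond the usual scatter, at least in this single pair. Nothing available here accounts for this outcome.

As far as these compounds go, whether this holds for groups of a different kind stays open: an amine, a carboxylic acid or a longer chain at this place could show whether the position responds to change at all, since one step inside the scatter sets no limit on it. Also open, from the compounds shown here alone, is whether the two groups would read alike on a different core, and whether the chlorine matters apart from the ring, which a plain phenyl group at this place could address.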